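Methoxy restored on the phenyl end of the dienone series

The source may report more compounds than this note shows. Statements on the series, on what has been measured and on what is new or still open speak of the compounds shown alone.

Compound 2 `COc1cc(/C=C/C(=O)/C=C/c2ccccc2)ccc1OCc1cn(CCOc2cc(=O)oc3ccccc23)nn1` stands lowest of the two numbers in hand: in a functional assay on THP-1 cells (Homo sapiens) for inhibition, read by sulforhodamine B assay, with a stated time of 48 h, tested at 50 uM (a higher number here means more inhibition of growth at the concentration tested, a lower number less inhibition of growth), compound 2 gives 61%, while compound 1 `COc1cc(/C=C/C(=O)/C=C/c2cc(OC)c(OC)c(OC)c2)ccc1OCc1cn(CCOc2cc(=O)oc3ccccc23)nn1` gives 99%. For the measured compounds named here, the one measured step, a number 38 percentage points lower from compound 1 to compound 2 (beyond the scatter), shows how much the growth inhibition fell when phenyl took the place of 3,4,5-trimethoxyphenyl.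

Compound 3 `COc1ccc(/C=C/C(=O)/C=C/c2ccc(OCc3cn(CCOc4cc(=O)oc5ccccc45)nn3)c(OC)c2)cc1` is not yet measured. Its change from compound 2, (methoxy in place of hydrogen on an aromatic carbon), puts a methoxy back onto the aromatic carbon, para to a large group. Going by the values given here, the only step that bears on this is the loss from compound 1 to compound 2; a single methoxy returns part of what three methoxy groups gave, so a rise in this assay is expected, smaller than that step. Compound 3 is expected to give 78%, with a range from 60% to 95%. This corresponds to an expected step of a number 17 percentage points higher from compound 2 to compound 3 (beyond the scatter).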

Compound 3, percent growth inhibition at one concentration: 78%
Estimate against measurement, compound 3: no gap at the digits printed; the range from low to high includes it.
By their numbers in this assay, from the lowest: compound 2; then compound 3; then compound 1.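

In this assay, a single methoxy on the aromatic carbon para to a large group is enough to recover growth inhibition, with a number 17 percentage points higher from compound 2 to compound 3 (beyond the scatter) as the step. The 4-methoxyphenyl end still does not match the 3,4,5-trimethoxyphenyl end, with a number 21 percentage points lower from compound 1 to compound 3 (beyond the scatter) as the step, so this one methoxy accounts for only part of the difference between the phenyl and 3,4,5-trimethoxyphenyl compounds. No supporting measurement is available to explain either step.

The compounds shown leave open whether the gain is specific to methoxy or would also appear with another group on this carbon, such as an amine or a hydroxyl. They also do not show how a dimethoxyphenyl end would fall relative to the two ends compared here.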